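The source may hold more compounds than are shown below. What is called first, only, known or untested is meant among the compounds shown, and "the series" means these compounds.

Measured compounds:
- compound 1 `C=CC1=C(C(=O)NCc2ccccc2)C(c2ccc(OC)c(OC)c2)OC1`; in a functional assay on A549 cells (Homo sapiens) for cytotoxicity, read by MTT assay, with a stated time of 24 h (on this read-out higher numbers stand for weaker inhibition and lower numbers for stronger inhibition), compound 1 gives > 100000 nM, a limit of the assay.
- compound 2 `C=CC1=C(C(=O)NCc2ccccc2)C(c2ccc(OC)cc2)OC1`; in this assay compound 2 gives > 100000 nM, again a limit.
- compound 3 `C=CC1=C(C(=O)NCc2ccc(C)cc2)C(c2ccc(F)cc2)OC1`; in this assay compound 3 gives > 100000 nM, also a limit.

Compound 2 therefore stands only at the limit, with no number of its own. For the measured compounds named here, the single step between measured compounds, a step that the two limits leave unreadable from compound 1 to compound 2, is unreadable for the same reason, as the limit of > 100000 nM in this assay, at which 3 of the 3 values shown sit, sums up. Compound 4 `C=CC1=C(C(=O)NC2CCCCC2)C(c2ccc(OC)cc2)OC1` differs from compound 2 by cyclohexyl in place of benzyl on an amide-type nitrogen. Going by the values given here, no measured step bears on this change, and every value shown is a limit, so no step beyond the scatter can be expected in either direction. Compound 4 is expected at about 200000 nM, range 60000 nM to 1000000 nM, most likely reported only as a limit. The expected step is a step that the limit leaves unreadable from compound 2 to compound 4.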

Compound 4, half-maximal inhibitory concentration: > 100000 nM
Compound 4: no number, only a limit; the forecaster's own chance of this, stated with the estimate: 85%; the middle value lies beyond the limit too.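

Compound 2 and compound 4 both stand only at a limit, so no step can be read for cyclohexyl in place of benzyl: the limit of > 100000 nM in this assay, at which 4 of the 4 values shown sit.

The compounds shown leave open whether any change to the shared core gives a number in this assay rather than a limit.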